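Working notes: 3-chlorophenyl to 4-bromophenyl

The compounds below may be only part of what the source reports. "The series", "measured", "known", "first", "only" and "open" are said of these compounds alone.

Measured so far in a functional assay on LoVo cells (Homo sapiens) for inhibition, read by MTT assay, with a stated time of 24 h (a higher number here means a weaker inhibitor, a lower number a stronger inhibitor), for this series:
- compound 1 `CC1(C)[C@H]2CC[C@]1(C)N(Cc1cn(-c3ccc(F)cc3)nn1)C(=O)C2` gives 40 nM
- compound 2 `CC1(C)[C@H]2CC[C@]1(C)N(Cc1cn(-c3cccc(Cl)c3)nn1)C(=O)C2` gives 70 nM

On these numbers, compound 2 is not separated from compound 1. Compound 3 `CC1(C)[C@H]2CC[C@]1(C)N(Cc1cn(-c3ccc(Br)cc3)nn1)C(=O)C2` differs from compound 2 by 4-bromophenyl in place of 3-chlorophenyl on an aromatic nitrogen in the group on an aromatic nitrogen. Within the data shown here, the one measured step at that nitrogen is a 1.8-fold higher number from compound 1 to compound 2 (0.24 log units; within the scatter) and bears directly on this change. No step beyond the scatter is therefore expected in this assay here. The estimated 1.4-fold lower number from compound 2 to compound 3 (0.15 log units; within the scatter) is the working expectation. For compound 3 the estimate is 50 nM with an expected range of 20 nM to 130 nM in this measurement.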

Compound 3, half-maximal inhibitory concentration: 60 nM
Compound 3: middle estimate off by 1.2-fold (0.08 log units), on the low side; measured number inside the range.
By their numbers in this assay, from the lowest: compounds 1, 3 and 2 (each within the scatter of the next).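

In this assay, 4-bromophenyl in place of 3-chlorophenyl on the aromatic nitrogen gives a 1.2-fold lower number from compound 2 to compound 3 (0.07 log units; within the scatter) and bromo in place of fluoro on an aromatic carbon gives a 1.5-fold higher number from compound 1 to compound 3 (0.18 log units; within the scatter). Across these three compounds, no halogen-bearing phenyl group at this nitrogen is separated from another, and the exchange of fluoro for bromo adds a second step within the scatter. No measurement at hand bears on a cause for this.

As far as these compounds go, whether a carboxylic acid or an amine on this phenyl group would stay within the scatter remains open. So does the effect of replacing the phenyl group with a longer alkyl chain.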